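From methoxy to 2-methoxyethoxy on compound 3

The source may report more compounds than this note shows. Statements on the series, on what has been measured and on what is new or still open speak of the compounds shown alone.

Of the compounds shown here, three have been read so far in an ADME assay on RAW264.7 cells (Mus musculus) for cytotoxicity, read by MTT assay, with a stated time of 24 h, in the absence of a further agent; a higher number here means a weaker inhibitor, a lower number a stronger inhibitor. Compound 1 (`O=C1OC(Cc2nc(Cc3ccccc3)no2)c2ccccc21`) gives > 40000 nM, which is a limit of the assay. Compound 2 (`O=C1OC(Cc2nc(-c3ccc(-c4ccccc4)cc3)no2)c2ccccc21`) gives > 40000 nM, also a limit. Compound 3 (`COc1ccc(C(O)C2OC(=O)c3c(OC)cc(OC)cc32)cc1`) gives > 40000 nM, again a limit, so it has no number of its own. Among the measured compounds shown here, the series so far stands at the limit of > 40000 nM in this assay, at which 3 of the 3 values shown sit.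

Compound 4 (`COCCOc1ccc(C(O)C2OC(=O)c3c(OC)cc(OC)cc32)cc1`) is still unmeasured. It carries methoxymethyl in place of hydrogen on a saturated chain carbon bound to an oxygen on an aromatic ring, which also reads as methoxy to 2-methoxyethoxy. For the measured compounds named here, no measured pair shows this change. The expectation therefore rests on compound 3, whose reading of > 40000 nM is a limit. No change beyond the scatter is expected in this assay, in either direction, the estimate being a step that the limit leaves unreadable from compound 3 to compound 4. For compound 4 the estimated value is 50000 nM, with an expected range of 25000 nM to 100000 nM.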

Compound 4, half-maximal inhibitory concentration: > 40000 nM
Compound 4: only a limit was reported; the forecaster's own chance of this, stated with the estimate: 85%; the middle value does not contradict the limit.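

In this assay, among the compounds shown here, compound 3 and compound 4 both read as limits of the assay, so no step from methoxy to 2-methoxyethoxy can be read. The compounds shown leave open whether this change affects the read-out at all, and every value shown remains a limit: the limit of > 40000 nM in this assay, at which 4 of the 4 values shown sit.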